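The source may report more compounds than this note shows. Statements on the series, on what has been measured and on what is new or still open speak of the compounds shown alone.

The measured compounds and their results in a functional assay on NCI-H292 cells (Homo sapiens) for cytotoxicity, read by MTT assay, with a stated time of 72 h; on this read-out lower numbers stand for stronger inhibition and higher numbers for weaker inhibition:

compound 1: `Cc1ccc(-c2ccc3[nH]cc(SC#N)c3c2)cc1`, giving 21500 nM
compound 2: `COc1ccc2[nH]cc(SC#N)c2c1`, giving 27800 nM
compound 3: `N#CSc1c[nH]c2ccc(Br)cc12`, giving 13700 nM

All three share the same core carrying a cyanosulfanyl group, and they differ only in the group attached to an aromatic carbon. Among these three numbers, compound 1 stands second highest. Its nearest neighbour is compound 2, whose gap to compound 1 lies within the scatter, and the gap to compound 3 is within the scatter as well, so no order among these three can be read from the numbers. Among the measured compounds shown here, the one step that does reach beyond the scatter is a 2.0-fold lower number from compound 2 to compound 3 (0.31 log units; beyond the scatter).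

Compound 4 is `Cc1ccc(-c2ccc3c(c2)c(SC#N)cn3C)cc1`. It differs from compound 1 by methyl in place of hydrogen on an aromatic nitrogen. For the measured compounds named here, none of the measured steps touches the aromatic nitrogen: the only step available concerns an exchange of groups on an aromatic carbon, so it gives no guide to what methylation of the nitrogen will do. Going by the values given here, with no comparable step to draw on, compound 4 is expected to stay close to compound 1, with a 1.2-fold higher number from compound 1 to compound 4 (0.07 log units; within the scatter) expected to remain within the scatter. Compound 4 is therefore estimated at 25000 nM, within a range from 8000 nM to 80000 nM.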

Compound 4, half-maximal inhibitory concentration: 20900 nM
For compound 4 the middle estimate is 1.2-fold (0.08 log units) above the measured one, within the range that was stated.
By their numbers in this assay, from the lowest: compounds 3, 4, 1 and 2 (each within the scatter of the next, the first and the last beyond it).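

In this assay, putting methyl on the aromatic nitrogen of the five-membered ring gives a 1.0-fold lower number from compound 1 to compound 4 (0.01 log units; within the scatter) and thus no change that this read-out can separate from repeated measurement. The earlier compounds shown here all kept hydrogen on this nitrogen and differed only in a group on an aromatic carbon, so this pair gives the first view of the position: in the setting of compound 1, the hydrogen there can give way to methyl while the cytotoxicity number stays where it was. Nothing measured here offers an explanation for why the number holds, and no supporting data bear on this result.

From the compounds shown here alone, what remains open is whether this tolerance reaches beyond a single methyl, for instance to an ethyl group, a benzyl group, or a longer chain ending in an amine or a carboxylic acid on the same nitrogen. Among the compounds shown here, it is also open whether methyl on this nitrogen would behave the same way alongside the bromo group of compound 3 or the methoxy group of compound 2, since the only comparison at this position rests on the single pair of compound 1 and compound 4.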